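From methyl to 3-chlorophenyl on the ring nitrogen

The compounds below may be only part of what the source reports. "The series", "measured", "known", "first", "only" and "open" are said of these compounds alone.

Measured in a toxicity assay on Huh-7 cells (Homo sapiens) for cytotoxicity, read by CCK-8 assay, with a stated time of 24 h; a higher number here means that more compound is tolerated, a lower number that less compound is tolerated:
compound 1 `CN1CCN(c2ccc(-c3cc(=O)c4c(O)c(O)c(O)cc4o3)cc2)CC1`: > 100000 nM, a limit
compound 2 `O=c1cc(-c2ccc(Nc3ccc(Br)cc3)cc2)oc2cc(O)c(O)c(O)c12`: > 100000 nM, a limit

Compound 1 stands only at a limit, not at a readable number. Compound 3 `O=c1cc(-c2ccc(N3CCN(c4cccc(Cl)c4)CC3)cc2)oc2cc(O)c(O)c(O)c12` has 3-chlorophenyl in place of methyl on an amine nitrogen in a ring. For the measured compounds named here, the one measured step, a step that the two limits leave unreadable from compound 1 to compound 2, puts (4-bromophenyl)amino in place of 4-methylpiperazin-1-yl. The evidence is a single ceiling: the limit of > 100000 nM in this assay, at which 2 of the 2 values shown sit. That step offers no size to carry over, so no change beyond the scatter is expected in this assay, and another limit is likely. The expected step is a number no higher from compound 1 to compound 3 (the limit leaves the size open). Compound 3 is estimated at 100000 nM, with an expected range of 40000 nM to 150000 nM.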

Compound 3, half-maximal cytotoxic concentration: > 100000 nM
Compound 3 gave a limit, no number (the forecaster's own chance of this, stated with the estimate: 70%); the middle value sits exactly at the limit.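

In this assay, for the compounds shown here, compound 1 and compound 3 both stand only at a limit, so no step between them can be read. The compounds shown leave open at what concentration any of them becomes toxic, and whether 3-chlorophenyl in place of methyl changes that: the limit of > 100000 nM in this assay, at which 3 of the 3 values shown sit.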